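Swapping 2,5-Dimethylphenyl for 2,6-Dichlorophenyl on a Shared Core

The source may report more compounds than this note shows. Statements on the series, on what has been measured and on what is new or still open speak of the compounds shown alone.

Three compounds have been measured in a functional assay on U-87MG ATCC cells for inhibition, with U-87 MG (Homo sapiens) as the target, read by MTT assay, with a stated time of 72 h; a higher number here means a weaker inhibitor, a lower number a stronger inhibitor:
Compound 1 `Cc1ccc(C)c(C(Nc2ccccn2)c2ccc3cccnc3c2O)c1` gives 13800 nM.
Compound 2 `Oc1c(C(Nc2ccccn2)c2c(Cl)cccc2Cl)ccc2cccnc12` gives 6900 nM.
Compound 3 `Cc1ccnc(NC(c2cc(C)ccc2C)c2ccc3cccnc3c2O)c1` reaches only a limit of the assay, > 10000 nM.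

Compound 2 differs from compound 1 by 2,6-dichlorophenyl in place of 2,5-dimethylphenyl on a saturated chain carbon bound to an aromatic carbon and a nitrogen on an aromatic ring; this gave a 2.0-fold lower number from compound 1 to compound 2 (0.30 log units; within the scatter). Compound 3 differs from compound 1 by methyl in place of hydrogen on an aromatic carbon; the step is a step that the limit leaves unreadable from compound 1 to compound 3, because compound 3 sits at the limit of > 10000 nM in this assay, at which 1 of the 3 values shown sits.

Compound 4 `Cc1ccnc(NC(c2ccc3cccnc3c2O)c2c(Cl)cccc2Cl)c1` is not yet measured. It differs from compound 3 by 2,6-dichlorophenyl in place of 2,5-dimethylphenyl on a saturated chain carbon bound to an aromatic carbon and a nitrogen on an aromatic ring, the same change that turned compound 1 into compound 2, at the same place. Resting on a 2.0-fold lower number from compound 1 to compound 2 (0.30 log units; within the scatter), the step from compound 3 is expected to be an at least 1.2-fold lower number from compound 3 to compound 4 (0.09 log units; that floor lies within the scatter), with compound 4 estimated at 8000 nM.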

Compound 4, half-maximal inhibitory concentration: 7200 nM
Compound 4: the middle estimate sits 1.1-fold (0.05 log units) above what was measured; the measured number falls inside the stated range.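

In this assay, compound 3 stands at a limit of the assay, > 10000 nM, and not at a true number. Carried onto this core, the swap of 2,5-dimethylphenyl for 2,6-dichlorophenyl gives an at least 1.3-fold lower number from compound 3 to compound 4 (0.14 log units; that floor lies within the scatter), which agrees with the result on the core of compound 1 but does not establish a real gain. The data show no conflict between the two cores, yet they do not show that the change carries over with the same size: the same change on two cores in this assay, a 2.0-fold lower number (0.30 log units; within the scatter) from compound 1 to compound 2 and an at least 1.3-fold lower number (0.14 log units; that floor lies within the scatter) from compound 3 to compound 4; the limit leaves it open whether they differ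

The methyl step, with 2,6-dichlorophenyl in place, gives a 1.0-fold higher number from compound 2 to compound 4 (0.02 log units; within the scatter), so that methyl shows no readable effect on this pair. As far as these compounds go, what a methoxy group or an amine at that aromatic carbon would do remains open.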